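A one-carbon extension of the alkyne side chain

This account rests on a few compounds, and the source may have more. Where it says the series, first, only, none or still open, it means among the compounds named here.

Compound 1 `O=C1C=C[C@@H](OC2CCCC2)O[C@@H]1CO`: 8000 nM
Compound 2 `C#CCO[C@@H]1C=CC(=O)[C@@H](CO)O1`: 15400 nM

Within the data shown here, compound 2 stands within the scatter of its only measured neighbour in a functional assay on HEp-2 cells (Homo sapiens) for inhibition, read by MTT assay, with a stated time of 72 h; a higher number here means a weaker inhibitor, a lower number a stronger inhibitor. The gap is a 1.9-fold higher number from compound 1 to compound 2 (0.28 log units; within the scatter). The next compound, compound 3 `C#CCCO[C@@H]1C=CC(=O)[C@@H](CO)O1`, differs from compound 2 as follows: propargyl in place of ethynyl on a saturated chain carbon bound to an oxygen on a saturated carbon. This places propargyl in place of ethynyl on a saturated chain carbon bound to an oxygen on a saturated carbon. Among the measured compounds shown here, only one measured step bears on this, the exchange of cyclopentyl for propargyl on an oxygen on a saturated carbon. That step stayed within the scatter, so no step beyond the scatter is expected in this assay, and no direction is favoured. The estimated step is a 1.2-fold lower number from compound 2 to compound 3 (0.07 log units; within the scatter). For compound 3 the expected value is 13000 nM, with an estimated range from 6500 nM to 26000 nM.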

Compound 3, half-maximal inhibitory concentration: 7100 nM
Beside the measured number, compound 3's estimate is 1.8-fold (0.26 log units) above it; low and high end bracket the measured number.
By their numbers in this assay, from the lowest: compounds 3, 1 and 2 (each within the scatter of the next, the first and the last beyond it).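

In this assay, among these compounds, going from propargyl to but-3-yn-1-yl on an oxygen on a saturated carbon gives a 2.2-fold lower number from compound 2 to compound 3 (0.34 log units; beyond the scatter), the only step here beyond the scatter, and a modest one. Exchanging cyclopentyl for but-3-yn-1-yl at this position gives a 1.1-fold lower number from compound 1 to compound 3 (0.05 log units; within the scatter), so these two groups cannot be ordered. Nothing available explains the step from the shorter alkyne chain to the longer one.

Two alkyne chains do not establish a trend with chain length. Going by these compounds, it remains open how a longer chain, an amine or a carboxylic acid would read at this position.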